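This account rests on a few compounds, and the source may have more. Where it says the series, first, only, none or still open, it means among the compounds named here.

Measured compounds:
compound 1 `CC(C)COc1cc(-c2ccccc2)nc2ccccc12` — > 4 ug/mL
compound 2 `Oc1cc(-c2ccccc2)nc2c(F)cccc12` — 0.53 ug/mL

In a functional assay on KB cells (Homo sapiens) for cytotoxicity (a higher number here means that more compound is needed for the effect, a lower number that less compound is needed), compound 1 reaches only the limit of the assay, > 4 ug/mL, so no number is known for it; it sits at the limit of > 4 ug/mL in this assay, at which 1 of the 2 values shown sits. In this assay compound 2 gives a numeric value, 0.53 ug/mL. The two compounds differ in more than one place, so nothing more than these two values can be said of the pair: one gives a number, the other only a limit.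

The next compound, compound 3 `CC(C)Oc1cc(-c2ccccc2)nc2ccccc12`, is not yet measured in this assay. It differs from compound 1 as follows: isopropyl in place of isobutyl on an oxygen on an aromatic ring. The change shortens the alkyl chain on the oxygen by one carbon and removes no donor or acceptor.

For so small a change on a compound that gave only a limit, the expected step that the limit leaves unreadable from compound 1 to compound 3 is none beyond the usual scatter, in no particular direction. Compound 3 is therefore expected at 5 ug/mL, in the range 2 ug/mL to 15 ug/mL, with a fair chance that the assay again reports only a limit.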

Compound 3, half-maximal effective concentration: 4.2 ug/mL
Beside the measured number, compound 3's estimate is 1.2-fold (0.08 log units) above it; the range from low to high includes it.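

No step from compound 1 to compound 3 can be read in this assay, as the value of compound 1 is only a limit: the limit of > 4 ug/mL in this assay, at which 1 of the 3 values shown sits.

The compounds shown leave open whether isopropyl in place of isobutyl on an oxygen on an aromatic ring changes the read-out at all, and in which direction.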